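Bromo substitution steps in a sulfonyl hydrazide series

A few compounds are considered here, and "the series" means these few. Any claim that something is new, unique, unknown or untested is made for them only; others in the source may bear on it.

Compound 1 `CC(=O)Nc1ccc(S(=O)(=O)NNc2ccc(F)cc2)cc1` gives 609 nM in an assay on HeLa cells for inhibition of Indoleamine 2,3-dioxygenase 1 (Homo sapiens), read by spectrophotometry, with a stated time of 24 h; on this read-out lower numbers stand for an effect already at smaller amounts and higher numbers for an effect only at larger amounts of compound. Compound 2 `CC(=O)Nc1ccc(S(=O)(=O)NNc2ccc(F)c(Br)c2)cc1` differs from compound 1 by bromo in place of hydrogen on an aromatic carbon, and in this assay compound 2 gives 2490 nM, so that the step is a 4.1-fold higher number from compound 1 to compound 2 (0.61 log units; beyond the scatter). Compound 3 `O=S(=O)(NNc1ccc(Br)cc1)c1ccccc1` stands on a second core; the difference between the two cores is not broken down here. In this assay compound 3 gives 128 nM, the lowest of the three numbers, with the others beyond the scatter from it.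

Compound 4 `O=S(=O)(NNc1ccc(Br)cc1)c1ccc(Br)cc1` is not yet measured. It differs from compound 3 by bromo in place of hydrogen on an aromatic carbon. This is the same kind of change as from compound 1 to compound 2, but not the same: there the bromo enters ortho to a fluoro group and meta to a large group, here it enters para to a large group. The change occurs only twice among these compounds, and only one measured step of it exists, a 4.1-fold higher number from compound 1 to compound 2 (0.61 log units; beyond the scatter), so the expectation for compound 4 rests on that single step, weakened by the different surroundings of the place. For compound 4 a step of a 2.0-fold higher number from compound 3 to compound 4 (0.29 log units; within the scatter) is expected in this assay, smaller than the measured one because a 4.1-fold higher number from compound 1 to compound 2 (0.61 log units; beyond the scatter) was taken at a place described differently. The estimate for compound 4 in this assay is 250 nM, expected to fall between 90 nM and 900 nM.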

Compound 4, half-maximal effective concentration: 374 nM
Compound 4: the middle estimate sits 1.5-fold (0.17 log units) below what was measured, within the range that was stated.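

In this assay, bromo in place of hydrogen on an aromatic carbon, here para to a large group, gives a 2.9-fold higher number from compound 3 to compound 4 (0.47 log units; beyond the scatter), so the number also rises on the core of compound 3. Across the two cores the steps run the same way and do not differ in size beyond the scatter: the same change on two cores in this assay, a 4.1-fold higher number (0.61 log units; beyond the scatter) from compound 1 to compound 2 and a 2.9-fold higher number (0.47 log units; beyond the scatter) from compound 3 to compound 4, 1.4-fold (0.15 log units) apart, within the scatter of two such steps. This supports carrying the change between these two cores in this assay, with a similar rise in the number for both pairs, but two steps make no general rule for the series, and they do not show why the number rises or whether the same step would appear at another place or on a further core.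

Open, from the compounds shown here alone, is whether a group other than bromo at the same place, such as chloro, methoxy, an amine or a carboxylic acid, would shift the number in the same way and to a similar extent. Also open is how much of the gap between the two cores belongs to each part of them, as the compounds shown hold no pair that differs in one place across the cores.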